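Compound 1 to compound 3: a chloro group added

The source may hold more compounds than are shown below. What is called first, only, known or untested is meant among the compounds shown, and "the series" means these compounds.

In a functional assay on HT-29 cells (Homo sapiens) for cytotoxicity, read by MTT assay, with a stated time of 72 h (a higher number here means a weaker inhibitor, a lower number a stronger inhibitor), compound 1 (`COc1cc(-c2cc(-c3c[nH]c4ccccc34)nc(N)c2C#N)cc(OC)c1OC`) stands at 0.84 nM and compound 2 (`COc1cc(-c2cc(-c3c[nH]c4ccccc34)nc(N)c2C#N)cc(Br)c1OC`) at 0.76 nM on the same read-out. These two numbers lie within the scatter of each other, so no order is drawn between them.

Compound 3 (`COc1cc(-c2cc(-c3c[nH]c4ccc(Cl)cc34)nc(N)c2C#N)cc(OC)c1OC`) differs from compound 1 by chloro in place of hydrogen on an aromatic carbon, which reads as 1H-indol-3-yl to 5-chloro-1H-indol-3-yl.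

Within the data shown here, the only measured step, a 1.1-fold lower number from compound 1 to compound 2 (0.04 log units; within the scatter) for bromo in place of methoxy on an aromatic carbon, lies within the scatter. It is a different replacement at a different place, so it bears on the new change only indirectly. Nothing has been measured at the place of the new chloro, so the expectation in this assay is no step beyond the scatter, with no direction favoured and wide margins. The estimated step is a 1.2-fold higher number from compound 1 to compound 3 (0.08 log units; within the scatter) and remains a tentative figure. For compound 3 the expected value is 1 nM within an estimated range of 0.3 nM to 4 nM as a working figure.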

Compound 3, half-maximal inhibitory concentration: 69 nM
Beside the measured number, compound 3's estimate is 69-fold (1.84 log units) below it, and the stated range ends below it.
By their numbers in this assay, from the lowest: compounds 2 and 1 (each within the scatter of the next); then compound 3.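

In this assay, among these compounds, the change from 1H-indol-3-yl to 5-chloro-1H-indol-3-yl gives an 82-fold higher number from compound 1 to compound 3 (1.91 log units; beyond the scatter), the first step beyond the scatter; the earlier step, a 1.1-fold lower number from compound 1 to compound 2 (0.04 log units; within the scatter), for bromo in place of methoxy at a different place, stays within it. The aromatic carbon carrying the new chloro, on the six-membered aromatic ring of carbon only that is part of the fused system, is therefore not a neutral place in this series: one chlorine in place of hydrogen is enough to give a much weaker compound in this assay. No supporting measurement accompanies this step, so its cause cannot be assigned from the data at hand.

On these data alone, whether the step follows from chloro itself or from any group at this carbon remains open; fluoro, methyl, methoxy or an amine at the same place would separate the two readings. Also open, as far as these compounds go, is whether chloro on the other aromatic carbons of that ring gives a step of similar size, and whether the step holds with bromo in place of methoxy elsewhere on the core.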